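This account rests on a few compounds, and the source may have more. Where it says the series, first, only, none or still open, it means among the compounds named here.

Compound 2 `CC1(C)C[C@@H](C(N)=O)N(Cc2ccc(OCc3cccc(F)c3)cc2)C1` and compound 1 `CC1(C)C[C@@H](C(N)=O)N(Cc2ccc(OCc3cccc(F)c3)cc2F)C1` share one core and differ in a single place: fluoro in place of hydrogen on an aromatic carbon. In an assay on Sf9 cells for inhibition of Amine oxidase [flavin-containing] B (Homo sapiens), with stated times of 15 min and 60 min (a higher number here means a weaker inhibitor, a lower number a stronger inhibitor), compound 2 gives 1420 nM, while compound 1 gives 6350 nM, so the step is a 4.5-fold higher number from compound 2 to compound 1 (0.65 log units; beyond the scatter). Compound 3 `NC(=O)[C@@H]1CCN1Cc1ccc(OCc2cccc(F)c2)cc1` is built on a different core; the difference between the two cores is not broken down here. In this assay compound 3 gives 21 nM, the lowest of the three numbers. Compound 4 `NC(=O)[C@@H]1CCN1Cc1ccc(OCc2cccc(F)c2)cc1F` is not yet measured and differs from compound 3 by fluoro in place of hydrogen on an aromatic carbon. This is the same kind of change as before, though the place is ortho to a (2-carbamoylazetidin-1-yl)methyl group and meta to a group of 9 heavy atoms, rather than ortho to a large group and meta to a (3-fluorobenzyl)oxy group. A step of similar size is expected, a 3.8-fold higher number from compound 3 to compound 4 (0.58 log units; beyond the scatter), because the like change earlier gave a 4.5-fold higher number from compound 2 to compound 1 (0.65 log units; beyond the scatter). Compound 4 is therefore estimated at 80 nM in this assay, with a likely range from 25 nM to 250 nM.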

Compound 4, half-maximal inhibitory concentration: 26 nM
Compound 4: the middle estimate sits 3.1-fold (0.49 log units) above what was measured, and the stated range covers the measured number.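

The same swap of fluoro for hydrogen, carried to another core, gives a 1.2-fold higher number from compound 3 to compound 4 (0.09 log units; within the scatter) in this assay, so this pair cannot be told apart. The size of the step therefore does not carry over from one core to the other: the same change on two cores in this assay, a 4.5-fold higher number (0.65 log units; beyond the scatter) from compound 2 to compound 1 and a 1.2-fold higher number (0.09 log units; within the scatter) from compound 3 to compound 4, 3.6-fold (0.56 log units) apart, beyond the scatter of two such steps. For the compounds shown here, with only two pairs, this shows that the outcome of the change depends on the core in these compounds, but not which part of the core is responsible or how any further core would respond.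

The compounds shown leave open whether chloro or methoxy in the same place would also differ between the two cores. Also open, going by these compounds, is how a carboxylic acid in place of the carbamoyl group would compare.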